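The source may report more compounds than this note shows. Statements on the series, on what has been measured and on what is new or still open speak of the compounds shown alone.

In an ADME assay on L929 cells (Mus musculus) for cytotoxicity, read by resazurin assay, with a stated time of 72 h (a higher number here means a weaker inhibitor, a lower number a stronger inhibitor), three compounds sharing one core have been read so far. Compound 1 `CC(=O)c1ccn(-c2ccc3c(c2)B(O)OC3)c1`, with methyl on the carbonyl carbon, gives > 10 ug/mL, which is a limit and not a number. Compound 2 `O=C(c1ccccc1)c1ccn(-c2ccc3c(c2)B(O)OC3)c1`, with phenyl in that place, gives > 10 ug/mL, again a limit. Compound 3 `O=C(c1ccn(-c2ccc3c(c2)B(O)OC3)c1)c1ccccc1Cl`, with 2-chlorophenyl there, gives > 10 ug/mL, also a limit, so it stands without a number of its own. All that the series shows so far is the limit of > 10 ug/mL in this assay, at which 3 of the 3 values shown sit.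

Compound 4 `O=C(c1ccc(Cl)cc1)c1ccn(-c2ccc3c(c2)B(O)OC3)c1` has the same atoms as compound 3, joined differently, with 4-chlorophenyl in place of 2-chlorophenyl on a carbonyl carbon. The closest measured change is a step that the two limits leave unreadable from compound 2 to compound 3, which also concerns the chloro group. The changes on the carbonyl carbon, a step that the two limits leave unreadable from compound 1 to compound 2 and a step that the two limits leave unreadable from compound 1 to compound 3, bear on it as well. None of the three has a readable size, and none points in a direction. No shift beyond the scatter is therefore expected in this assay, and the expected change is a step that the limit leaves unreadable from compound 3 to compound 4. Another report as a limit is the likeliest outcome. For compound 4 the estimated value is 15 ug/mL, with an expected range from 8 ug/mL to 40 ug/mL.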

Compound 4, half-maximal inhibitory concentration: > 10 ug/mL
Compound 4: only a limit was reported; the forecaster's own chance of this, stated with the estimate: 85%; the middle value is on the limit's open side.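

The steps linking compound 4 to compound 1, compound 2 and compound 3 cannot be read, and the series still shows only one limit: the limit of > 10 ug/mL in this assay, at which 4 of the 4 values shown sit. The compounds shown leave open where each one's true value lies, and whether any change on the carbonyl carbon shifts the reading in this assay at all.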